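Swapping Methyl for Isopropyl on an Aromatic Carbon

This account rests on a few compounds, and the source may have more. Where it says the series, first, only, none or still open, it means among the compounds named here.

In a physicochemical assay for lipophilicity, using the shake flask method, at pH 7.4 (on this read-out higher numbers stand for higher lipophilicity and lower numbers for lower lipophilicity), compound 3 `Cc1ccn2ncnc(N[C@H]3CC[C@H](N(C)C)CC3)c12` gives 0.2. This cannot be told apart from compound 1 `CN(C)[C@H]1CC[C@H](Nc2ncnn3ccc([C@H]4CC[C@@H](C(N)=O)CC4)c23)CC1` at 0.1. Compound 2 `Cn1ccc2ncnc(N[C@H]3CC[C@H](N(C)C)CC3)c21`, at -0.8, lies clearly lower than compound 3, and its core differs from theirs.

The next molecule, compound 4 `CC(C)c1ccn2ncnc(N[C@H]3CC[C@H](N(C)C)CC3)c12`, carries isopropyl in place of methyl on an aromatic carbon. Within the data shown here, only one measured step touches this carbon: a number 0.10 log units higher from compound 1 to compound 3 (within the scatter). That step stayed small, but the group leaving it was a 4-carbamoylcyclohexyl, which is very different from isopropyl, so it gives no direct measure of the present change. Among the measured compounds shown here, no measured pair here shows what adding carbon alone does. General experience with added carbon, rather than these data, therefore suggests a moderate rise in this assay, likely to exceed the scatter. The expected change is a number 0.70 log units higher from compound 3 to compound 4 (beyond the scatter). For compound 4 the estimated value is 0.9, with an expected range from 0.5 to 1.3.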

Compound 4, distribution coefficient: 1.3
The estimate for compound 4 lay 0.40 log units below the measured number, and the stated range covers the measured number.
By their numbers in this assay, from the lowest: compound 2; then compounds 1 and 3 (each within the scatter of the next); then compound 4.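

Changing methyl to isopropyl on this aromatic carbon of the five-membered ring moves the number clearly in this assay, with a number 1.10 log units higher from compound 3 to compound 4 (beyond the scatter), so a change of only two added carbons can register at this position. The earlier step at this carbon, a number 0.10 log units higher from compound 1 to compound 3 (within the scatter), gave no sign of this, and the new result also separates isopropyl from the far larger 4-carbamoylcyclohexyl, with a number 1.20 log units higher from compound 1 to compound 4 (beyond the scatter), so a bigger group here does not by itself give a higher number. The compounds shown offer no separate measurement that could explain the size of these steps.

Still open, on these data alone, is whether the number keeps rising with a longer chain such as propyl or butyl, or with a cyclopropyl ring at this carbon. An amine or a carboxylic acid in the same place also remains an open case.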